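The source may report more compounds than this note shows. Statements on the series, on what has been measured and on what is new or still open speak of the compounds shown alone.

Going by the values given here, compound 2 `COc1ccc(C(=O)/C=C/c2cc(-c3cc(OC)c(OC)c(OC)c3)n[nH]2)cc1` stands at the higher of the two numbers measured so far: in a functional assay on UACC-62 cells (Homo sapiens) for cytotoxicity, read by sulforhodamine B assay, with a stated time of 48 h, tested at 10 uM (on this read-out higher numbers stand for a weaker effect at the one concentration tested and lower numbers for a stronger effect), compound 2 gives -74%. Compound 1 `COc1ccc(C(=O)/C=C/c2cc(-c3cc(OC)c(OC)c(OC)c3)n[nH]2)cc1OC` shares the same core, and in this assay compound 1 gives -92%. Among the compounds with values here, the one measured step, a number 18 percentage points higher from compound 1 to compound 2 (beyond the scatter), came with hydrogen in place of methoxy on an aromatic carbon. Compound 3 `COc1cc(-c2cc(/C=C/C(=O)c3ccc(F)c(F)c3)[nH]n2)cc(OC)c1OC` has not been measured yet; it differs from compound 2 by 3,4-difluorophenyl in place of 4-methoxyphenyl on a carbonyl carbon. Within the data shown here, only that one step bears on this change, since it altered the 4-methoxyphenyl that now leaves, and it was modest. Among the measured compounds shown here, no measured compound carries a fluorine-bearing ring, so the direction is uncertain. The expected step is a number 9 percentage points higher from compound 2 to compound 3 (within the scatter), which may not exceed the scatter. The estimate for compound 3 in this assay is -65%, with a range from -90% to -30%.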

Compound 3, a percentage reported as activity, at one concentration (the size of the read-out at that concentration, not a potency): -13%
Compound 3: middle estimate off by 52 percentage points, on the low side; measured number above the stated range.
By their numbers in this assay, from the lowest: compound 1; then compound 2; then compound 3.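

The group on the carbonyl carbon matters far more than the first step suggested: in this assay, losing one methoxy gave only a number 18 percentage points higher from compound 1 to compound 2 (beyond the scatter), whereas replacing the whole ring substituent pattern with fluorines gives a number 61 percentage points higher from compound 2 to compound 3 (beyond the scatter) and a number 79 percentage points higher from compound 1 to compound 3 (beyond the scatter). Since higher numbers mean a weaker effect, both fluorine-bearing changes remove much of the effect, although the entering 3,4-difluorophenyl has the same ring and heavy-atom count as the 4-methoxyphenyl it replaces. No measurement shown explains why this exchange costs so much.

Going by these compounds, it remains open whether the loss follows from the arrival of fluorine or the departure of methoxy, which a plain phenyl ring could help to separate. Nor do these compounds show how a ring carrying a hydroxyl or an amine would behave at this position.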